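This account rests on a few compounds, and the source may have more. Where it says the series, first, only, none or still open, it means among the compounds named here.

Two compounds share one core. Compound 1 `COc1ccc(Cn2cc(CSC(=S)N3CCN(C(=O)OCc4ccccc4)CC3)nn2)cc1` gives 58300 nM in a functional assay on ECa-109 cells (Homo sapiens) for inhibition, read by MTT assay, with a stated time of 72 h; a higher number here means a weaker inhibitor, a lower number a stronger inhibitor. Within the data shown here, compound 2 `O=C(OCc1ccccc1)N1CCN(C(=S)SCc2cn(Cc3ccc(F)cc3)nn2)CC1`, in this assay, gives 32000 nM; the one measured step, a 1.8-fold lower number from compound 1 to compound 2 (0.26 log units; within the scatter), is the only guide to how changes at this position behave, and it stays within the scatter. Compound 2 thus holds the lowest of the two numbers, though its gap to compound 1 is not one beyond the scatter.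

Compound 3 `COc1cc(Cn2cc(CSC(=S)N3CCN(C(=O)OCc4ccccc4)CC3)nn2)cc(OC)c1OC` is not yet measured. It differs from compound 2 by 3,4,5-trimethoxyphenyl in place of 4-fluorophenyl on a saturated chain carbon bound to an aromatic nitrogen. Among the measured compounds shown here, the single measured step at this position, from fluoro to methoxy, moved the number only within the scatter, so a further methoxy-bearing replacement here is expected to move this assay by no more than the scatter as well. Compound 3 is therefore estimated to give 45000 nM in this assay, within 15000 nM to 130000 nM, a step of a 1.4-fold higher number from compound 2 to compound 3 (0.15 log units; within the scatter).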

Compound 3, half-maximal inhibitory concentration: > 128000 nM
Compound 3: only a limit was reported; the forecaster's own chance of this, stated with the estimate: 15%; middle value at least 2.8-fold (0.45 log units) from the limit.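

Compound 3 gives only a limit in this assay, not a number: the limit of > 128000 nM in this assay, at which 1 of the 3 values shown sits.

Even so, this position now shows steps beyond the scatter, an at least 4.0-fold higher number from compound 2 to compound 3 (0.60 log units; beyond the scatter) and an at least 2.1-fold higher number from compound 1 to compound 3 (0.34 log units; beyond the scatter), whereas the one earlier step here, a 1.8-fold lower number from compound 1 to compound 2 (0.26 log units; within the scatter), stayed within it. The earlier pair could not show that this place responds to the group it carries, but 3,4,5-trimethoxyphenyl on this saturated chain carbon gives a weaker inhibitor than either 4-fluorophenyl or 4-methoxyphenyl, by a margin that is only a lower bound.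

The compounds shown leave open how far compound 3 really lies from the other two, and so the true size of both steps. They also leave open how a plain phenyl, or a phenyl bearing an amine or a carboxylic acid, would read in this assay at this place.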